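This account rests on a few compounds, and the source may have more. Where it says the series, first, only, none or still open, it means among the compounds named here.

Within the data shown here, in a physicochemical assay for solubility, measured as kinetic solubility, at pH 6.5 (a higher number here means a more soluble compound, a lower number a less soluble compound), compound 1 (`C[C@@H](c1c[nH]c2ncccc12)c1nnc2ccc(-c3cnn(C)c3)nn12`) gives 150000 nM as the highest of the three numbers so far. Compound 2 (`Fc1ccc(-c2ccc3nnc(Cc4ccc5ncccc5c4)n3n2)cc1F`) gives 11500 nM and compound 3 (`CNC(=O)c1ccc(-c2ccc3nnc([C@@H](C)c4ccc5ncccc5c4)n3n2)cc1`) gives 11000 nM in the same test. These two sit within the scatter of each other, and both lie well beyond the scatter from compound 1.

Compound 4 (`CCNc1ccc2nnc([C@@H](C)c3c[nH]c4ncccc34)n2n1`) has ethylamino in place of 1-methyl-1H-pyrazol-4-yl on an aromatic carbon of the core of compound 1 (ethylamino in place of 1-methyl-1H-pyrazol-4-yl on an aromatic carbon). Among the measured compounds shown here, no measured pair isolates this change, since compound 2 and compound 3 each differ from compound 1 in more than one place, so the expectation is a weak one. For the measured compounds named here, compound 1 stands at 150000 nM as the top of the numbers seen, so a small fall is the more likely direction, with no step clearly beyond the scatter. The estimated step is a 1.9-fold lower number from compound 1 to compound 4 (0.27 log units; within the scatter) on this reading. In this assay the expected value for compound 4 is 80000 nM with an estimated range from 25000 nM to 170000 nM around it.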

Compound 4, solubility: 426000 nM
For compound 4 the middle estimate is 5.3-fold (0.73 log units) below the measured one; measured number outside the range, above it.
By their numbers in this assay, from the lowest: compounds 3 and 2 (each within the scatter of the next); then compound 1; then compound 4.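

In this assay, among these compounds, ethylamino in place of 1-methyl-1H-pyrazol-4-yl on this aromatic carbon gives a 2.8-fold higher number from compound 1 to compound 4 (0.45 log units; beyond the scatter), the only single-place step so far. The value of compound 1 is therefore not a ceiling for this position, and a five-membered aromatic ring is not needed here to reach the high end of the numbers. No measurement on hand accounts for the rise, and this one step cannot separate the loss of the ring, the smaller heavy-atom count and the added hydrogen-bond donor.

As far as these compounds go, whether the gain is specific to ethylamino remains open; methylamino, a longer chain such as butylamino or a cyclic amine such as morpholine at this carbon would test that. Also open, from the compounds shown here alone, is whether the same change carries over to the other substitution patterns of compound 2 and compound 3.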